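Chloro at the pyridine of compound 2

The compounds below may be only part of what the source reports. "The series", "measured", "known", "first", "only" and "open" are said of these compounds alone.

Compound 1, `CCOc1ccc(C(=O)Nc2cc(C)cc(C)n2)cc1`, 17400 nM; compound 2, `C=CCOc1ccc(C(=O)Nc2ccccn2)cc1`, 61400 nM; compound 3, `CCCOc1ccc(C(=O)Nc2cccc(C)n2)cc1`, 11100 nM.

In an in vitro assay on HEK-tsA201 cells for antagonist activity at Neuronal acetylcholine receptor; alpha3/beta4 (Homo sapiens), read by fluorescence and calcium flux (on this read-out lower numbers stand for stronger inhibition and higher numbers for weaker inhibition), compound 2 gives the highest number of the three, and its gaps to compound 1 and to compound 3 both lie beyond the scatter. The next compound, compound 4, `C=CCOc1ccc(C(=O)Nc2cccc(Cl)n2)cc1`, differs from compound 2 by chloro in place of hydrogen on an aromatic carbon. Going by the values given here, no measured pair shows this change, so the size of the step is not known. Compounds 1 and 3, which carry a group on the same ring, give lower numbers than compound 2, so the step from compound 2 to compound 4 is expected to go toward stronger inhibition, by a 2.5-fold lower number from compound 2 to compound 4 (0.39 log units; beyond the scatter). For compound 4 the estimate in this assay is 25000 nM, with a range from 8000 nM to 70000 nM.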

Compound 4, half-maximal inhibitory concentration: > 100000 nM
Compound 4 gave a limit, no number; the forecaster's own chance of this, stated with the estimate: 15%; middle value at least 4.0-fold (0.60 log units) away from the limit.
By their numbers in this assay, from the lowest: compounds 3 and 1 (each within the scatter of the next); then compound 2. At a limit, above all of these: compound 4.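

In this assay compound 4 gives > 100000 nM, which is a limit of the assay and not a number. Chloro in place of hydrogen on this aromatic carbon next to the ring nitrogen therefore gives an at least 1.6-fold higher number from compound 2 to compound 4 (0.21 log units; that floor lies within the scatter), the first direct reading of this change at this position. Only a floor can be read for this step: the limit of > 100000 nM in this assay, at which 1 of the 4 values shown sits.

Going by these compounds, whether fluoro, methoxy or an amine on the same carbon would give a lower or higher number than compound 2 remains open.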